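The compounds below may be only part of what the source reports. "The series", "measured", "known", "first", "only" and "open" are said of these compounds alone.

Measured so far in a functional assay on NIH3T3 cells (Mus musculus); a higher number here means that more compound is needed for the effect, a lower number that less compound is needed:
- compound 1 `Cn1cncc1C(OCc1nc(N2CCC(C(N)=O)CC2)c(C#N)cc1-c1cccc(Cl)c1)c1ccc(C#N)cc1` gives 1.5 nM
- compound 2 `Cn1cncc1C(OCc1ccc(C#N)nc1-c1ccc(OC(F)(F)F)cc1)c1ccc(C#N)cc1` gives 4 nM
- compound 3 `Cn1cncc1C(OCc1ccc(C#N)cc1-c1cc(F)cc(F)c1)c1ccc(C#N)nc1` gives 25 nM

Compound 2, at 4 nM, is the middle one of the three. Compound 1 lies lower and compound 3 lies higher, and both gaps are beyond the scatter.

The next compound to be read is compound 4 `Cn1cncc1C(OCc1ccc(C#N)nc1-c1cc(Cl)cc(Cl)c1)c1ccc(C#N)cc1`. It keeps the rest of compound 2 and carries 3,5-dichlorophenyl in place of 4-(trifluoromethoxy)phenyl on an aromatic carbon. The change sits on a six-membered aromatic ring with 1 nitrogen, next to the ring nitrogen, ortho to a large group and meta to a cyano group.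

Going by the values given here, no measured pair differs in one place only, so this swap has no direct precedent. Compound 1 and compound 3 differ from compound 2 in more than one place, and they serve only as outer guides to the spread of the series. In this assay a small change is expected, with no firm direction and probably within the scatter, and the estimated step runs a 1.3-fold higher number from compound 2 to compound 4 (0.10 log units; within the scatter). The estimate for compound 4 is 5 nM, with an expected range of 1.5 nM to 18 nM.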

Compound 4, half-maximal effective concentration: 6 nM
Compound 4: middle estimate off by 1.2-fold (0.08 log units), on the low side; the measured number falls inside the stated range.
By their numbers in this assay, from the lowest: compound 1; then compounds 2 and 4 (each within the scatter of the next); then compound 3.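

In this assay, going by these compounds alone, the exchange of 4-(trifluoromethoxy)phenyl for 3,5-dichlorophenyl gives a 1.5-fold higher number from compound 2 to compound 4 (0.18 log units; within the scatter), the first step that changes one place only, and it stays within the scatter. On this aromatic carbon, next to the ring nitrogen, ortho to a large group and meta to a cyano group, the two substituted phenyl groups therefore cannot be told apart in this read-out, although 11 heavy atoms leave and 8 enter. Nothing available explains this equivalence or ties it to any property of either group.

The compounds shown leave open whether the position holds up with groups other than these two substituted phenyls, such as an unsubstituted phenyl, or a phenyl carrying an amine or a carboxylic acid. From the compounds shown here alone, it also remains open whether the same exchange would give a similar step on the core of compound 1 or of compound 3, each of which differs from compound 2 in more than one place.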